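A Cyano Group Enters Where Three Compounds Sit at the Limit

The compounds below may be only part of what the source reports. "The series", "measured", "known", "first", "only" and "open" are said of these compounds alone.

Compound 1 `CN(CCN(C)C(=O)n1cccn1)Cc1ccc(OCc2ccccc2)cc1`, compound 2 `Cc1cnn(C(=O)N(C)CCN(C)Cc2cccc(OCc3ccccc3)c2)c1` and compound 3 `CN(CCN(C)C(=O)n1cccn1)Cc1cccc(OCc2ccccc2)c1` were tested in an assay on membranes from brain for binding affinity to neutral cholesterol ester hydrolase 1 (Mus musculus), read by fluorescence, with stated times of 1 h and 30 min; on this read-out higher numbers stand for weaker inhibition and lower numbers for stronger inhibition. Compound 1 reaches only the limit of the assay, giving > 100000 nM. Compound 2 likewise gives only the limit, > 100000 nM. Compound 3 also gives only a limit, > 100000 nM, so its standing among the three cannot be read as a number. The step that the two limits leave unreadable from compound 2 to compound 3 is unreadable, which follows from the limit of > 100000 nM in this assay, at which 3 of the 3 values shown sit. Compound 4 `CN(CCN(C)C(=O)n1cc(C#N)cn1)Cc1cccc(OCc2ccccc2)c1` is reached by cyano in place of hydrogen on an aromatic carbon. Among the compounds with values here, no measured step offers a readable size for this change. The step of a number no higher from compound 3 to compound 4 (the limit leaves the size open) is therefore expected to leave the result at a limit once more. Compound 4 is estimated at 100000 nM in this assay, with a range from 20000 nM to 500000 nM.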

Compound 4, half-maximal inhibitory concentration: > 100000 nM
Compound 4: no number, only a limit; the forecaster's own chance of this, stated with the estimate: 85%; the middle value sits exactly at the limit.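

In this assay compound 4 gives > 100000 nM, which is a limit and not a number. No step from compound 2 or compound 3 to compound 4 can be read: the limit of > 100000 nM in this assay, at which 4 of the 4 values shown sit.

The compounds shown leave open how large the step from hydrogen to cyano is, and whether any of these structures gives a readable value in this assay.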